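The source may report more compounds than this note shows. Statements on the series, on what has been measured and on what is new or still open speak of the compounds shown alone.

Measured compounds: compound 1 `Cc1nc(-c2ccccc2)sc1C(=O)CSc1nc(N)c(C#N)c(-c2ccccc2)n1` with 26.3%; compound 2 `Cc1nc(-c2ccc(Cl)cc2)sc1C(=O)CSc1nc(N)c(C#N)c(-c2ccc(Cl)cc2)n1` with 15.5%; compound 3 `COc1ccc(-c2nc(SCC(=O)c3sc(-c4ccc(Cl)cc4)nc3C)nc(N)c2C#N)cc1` with 17.8%.

In a functional assay on U-87MG ATCC cells for antiproliferative activity against U-87 MG (Homo sapiens), read by MTT assay, with a stated time of 48 h, tested at 50 uM (a lower number here means a stronger effect, a higher number a weaker effect of the compound at the concentration tested), compound 3 stands second highest of the three numbers, nearest to compound 2 and furthest from compound 1, both gaps within the scatter. Compound 4 `Cc1nc(-c2ccc(Cl)cc2)sc1C(=O)CSc1nc(N)c(C#N)c(-c2ccccc2)n1` differs from compound 3 by hydrogen in place of methoxy on an aromatic carbon. Among the compounds with values here, the only measured step at this position, a number 2.3 percentage points higher from compound 2 to compound 3 (within the scatter), was within the scatter, and compound 1 and compound 3 show numbers within the scatter of each other as well. Compound 4 is therefore expected to land close to compound 3, with a number 2.2 percentage points higher from compound 3 to compound 4 (within the scatter) as the estimated step, no direction beyond the scatter. Compound 4 is estimated at 20%, between 12% and 30%.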

Compound 4, a percentage reported as activity, at one concentration (the size of the read-out at that concentration, not a potency): 15.2%
Estimate against measurement, compound 4: 4.8 percentage points above; the range from low to high includes it.
By their numbers in this assay, from the lowest: compounds 4, 2, 3 and 1 (each within the scatter of the next, the first and the last beyond it).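

With the chloro kept on the other aromatic ring, this assay now shows hydrogen, chloro and methoxy all reading alike at this position: the change to phenyl gives a number 2.6 percentage points lower from compound 3 to compound 4 (within the scatter) and hydrogen in place of chloro gives a number 0.3 percentage points lower from compound 2 to compound 4 (within the scatter) for this position. Within the data shown here, the only step beyond the scatter lies on the other ring, where chloro in place of hydrogen gives a number 11.1 percentage points lower from compound 1 to compound 4 (beyond the scatter) and is modest in size. Nothing available accounts for this difference between the two rings. Going by these compounds, whether an amine or a carboxylic acid at this position would move the number remains open.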